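This account rests on a few compounds, and the source may have more. Where it says the series, first, only, none or still open, it means among the compounds named here.

Measured compounds and their values:
- compound 1 `CC[C@@H](NC(=O)CC(C)C)C(=O)N1CCC(c2ccc(Cl)cc2)CC1`: 152 nM
- compound 2 `CC(C)[C@@H](NC(=O)c1cccc(F)c1)C(=O)N1CCC(c2ccc(Cl)cc2)CC1`: 24 nM
- compound 3 `CCCC(NC(=O)c1ccccc1C)C(=O)N1CCC(c2ccc(Cl)cc2)CC1`: 152 nM

These three compounds were tested in an assay on THP-1 cells for displacement of a labelled ligand from C-C chemokine receptor type 1 (Homo sapiens); on this read-out lower numbers stand for stronger inhibition and higher numbers for weaker inhibition. Compound 2 stands at the lowest number of the three, and its distance from both compound 1 and compound 3 is beyond the usual scatter of repeated measurements, so among these three it is the strongest binder. No single-point comparison between measured compounds is available, so nothing can be said about what any one change does on its own.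

Compound 4 `CC(C)[C@@H](NC(=O)c1cc2ccccc2s1)C(=O)N1CCC(c2ccc(Cl)cc2)CC1` has not yet been measured. It differs from compound 2 in one place: 1-benzothiophen-2-yl in place of 3-fluorophenyl on a carbonyl carbon. The shared core and the rest of the molecule stay the same.

Without a measured step of this kind, the expectation rests on compound 2 alone. The change is expected to leave the number roughly where compound 2 is, with a step of a 1.3-fold higher number from compound 2 to compound 4 (0.10 log units; within the scatter) that could fall on either side within the scatter. For compound 4 the estimated value in this assay is 30 nM, with a likely range from 8 nM to 120 nM.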

Compound 4, half-maximal inhibitory concentration: 58 nM
For compound 4 the middle estimate is 1.9-fold (0.29 log units) below the measured one, and the stated range covers the measured number.
By their numbers in this assay, from the lowest: compound 2; then compound 4; then compounds 1 and 3 (each within the scatter of the next).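

Going by these compounds alone, on the carbonyl carbon, replacing 3-fluorophenyl with 1-benzothiophen-2-yl gives the first single-change comparison in this assay: it produces a 2.4-fold higher number from compound 2 to compound 4 (0.38 log units; beyond the scatter) and so a modest weakening. This position can therefore carry a group with one five-membered and one six-membered aromatic ring and still give a measurable value, but here that group does not improve on 3-fluorophenyl. Nothing measured here accounts for this step, and the roles of the added ring, the sulfur and the lost fluorine cannot be separated.

The compounds shown leave open how an unsubstituted phenyl or a pyridine ring would compare at this position, and whether either would match 3-fluorophenyl. As far as these compounds go, it also remains unknown whether the same step would appear with the side chain of compound 1 or compound 3.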